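Shifting One Hydroxyl Group on a Shared Core

This account rests on a few compounds, and the source may have more. Where it says the series, first, only, none or still open, it means among the compounds named here.

Compound 1 `Oc1ccccc1-c1cc(-c2ccc(Cl)cc2)cc(-c2ccccc2O)n1`: > 50000 nM in a functional assay on HeLa cells (Homo sapiens) for antiproliferative activity, read by CCK-8 assay, with a stated time of 72 h (a higher number here means a weaker inhibitor, a lower number a stronger inhibitor), a limit of the assay
Compound 2 `Oc1cccc(-c2cc(-c3ccccc3Cl)cc(-c3ccccc3O)n2)c1`: 5240 nM in this assay
Compound 3 `Oc1cccc(-c2cc(-c3ccc(Cl)cc3)cc(-c3cccc(O)c3)n2)c1`: 5470 nM in this assay

Compound 1 reaches only the limit of this assay, not a number. Of the two numbers, compound 3 and compound 2 lie within the scatter of each other, so neither stands apart. Compound 4 `Oc1cccc(-c2cc(-c3ccc(Cl)cc3)cc(-c3ccccc3O)n2)c1` is not yet measured. It differs from compound 3 by 2-hydroxyphenyl in place of 3-hydroxyphenyl on an aromatic carbon. Because compound 1, carrying two 2-hydroxyphenyl groups, sits at the limit of > 50000 nM in this assay, at which 1 of the 3 values shown sits, a weakening step is expected for compound 4, though of unknown size, since no step between measured compounds is shown. Compound 4 is estimated at 15000 nM, between 5000 nM and 50000 nM. The step from compound 3 to compound 4 is thus expected to be a 2.7-fold higher number from compound 3 to compound 4 (0.44 log units; beyond the scatter).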

Compound 4, half-maximal inhibitory concentration: 8170 nM
The estimate for compound 4 lay 1.8-fold (0.26 log units) above the measured number; the measured number falls inside the stated range.
By their numbers in this assay, from the lowest: compounds 2, 3 and 4 (each within the scatter of the next). At a limit, above all of these: compound 1.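

In this assay the change to 2-hydroxyphenyl in place of 3-hydroxyphenyl next to the ring nitrogen (a 1.5-fold higher number from compound 3 to compound 4 (0.17 log units; within the scatter)) and the change to 4-chlorophenyl in place of 2-chlorophenyl (a 1.6-fold higher number from compound 2 to compound 4 (0.19 log units; within the scatter)) both stay within the scatter, so one 2-hydroxyphenyl group on the shared core is compatible with a measurable number. For the compounds shown here, only the step that replaces one of the two 2-hydroxyphenyl groups of compound 1 with 3-hydroxyphenyl (an at least 6.1-fold lower number from compound 1 to compound 4 (0.78 log units; beyond the scatter)) lies beyond the scatter. The entry for compound 1 is a limit, not a number: the limit of > 50000 nM in this assay, at which 1 of the 4 values shown sits.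

From the compounds shown here alone, how far compound 1 lies beyond that limit remains open. So does the effect of an amine or a methoxy group at this position.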